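The source may report more compounds than this note shows. Statements on the series, on what has been measured and on what is new or still open speak of the compounds shown alone.

For the measured compounds named here, compound 1 `COc1ccc2c(c1)NC(=O)CN2c1nc(NCCCO)nc2ccccc12` is one of two compounds measured in a functional assay on KB cells (Homo sapiens) for inhibition, read by sulforhodamine B assay, with a stated time of 48 h; on this read-out lower numbers stand for stronger inhibition of growth and higher numbers for weaker inhibition of growth. In this assay compound 1 gives 4.92 nM, the lower of the two numbers, while compound 2 `CCCCNc1nc(N2CC(=O)Nc3cc(OC)ccc32)c2ccccc2n1` gives 5.25 nM; the two values lie within the scatter of each other. The step of a 1.1-fold higher number from compound 1 to compound 2 (0.03 log units; within the scatter) placed methyl in place of hydroxy on a saturated chain carbon. Compound 3 `COc1ccc2c(c1)NC(=O)CN2c1nc(NC2CCCC2)nc2ccccc12` differs from compound 1 in one place: cyclopentyl in place of 3-hydroxypropyl on a nitrogen on an aromatic ring. Going by the values given here, the only measured step that bears on this change is the one from compound 1 to compound 2, which also removed the hydroxy from the same chain and left the number essentially where it was. Because a 1.1-fold higher number from compound 1 to compound 2 (0.03 log units; within the scatter) showed no movement beyond the scatter, compound 3 is expected to show a 1.1-fold higher number from compound 1 to compound 3 (0.05 log units; within the scatter), that is, no step beyond the scatter. The estimate for compound 3 is therefore 5.5 nM, with a range from 2.2 nM to 14 nM.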

Compound 3, concentration for 50% growth inhibition in the KB assay: 6.92 nM
Estimate against measurement, compound 3: 1.3-fold (0.10 log units) below; the measured number falls inside the stated range.
By their numbers in the KB assay, from the lowest: compounds 1, 2 and 3 (each within the scatter of the next).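

In the KB assay, the ring now set against both open chains gives a 1.4-fold higher number from compound 1 to compound 3 (0.15 log units; within the scatter) and a 1.3-fold higher number from compound 2 to compound 3 (0.12 log units; within the scatter), so among these three compounds the nitrogen on the aromatic ring carries 3-hydroxypropyl, butyl or cyclopentyl with no step beyond the scatter. In a physicochemical assay for lipophilicity, read by HPLC, measured as octanol-water partition, tested at 1 mg/mL (on this read-out lower numbers stand for lower lipophilicity and higher numbers for higher lipophilicity), compound 1 gives 2.6 and compound 3 gives 2.33, which is a number 0.27 log units lower from compound 1 to compound 3 (within the scatter) and so also no step beyond the scatter, even though cyclopentyl has no hydrogen-bond donor or acceptor. No measurement shown explains why the numbers in the KB assay stay so close.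

As far as these compounds go, all three compounds share one core, so it remains open whether this tolerance holds on another core. From the compounds shown here alone, it also remains open how an amine or a carboxylic acid at the end of the chain, or a longer chain, would behave at this nitrogen.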